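The source may report more compounds than this note shows. Statements on the series, on what has been measured and on what is new or still open speak of the compounds shown alone.

Compound 1 `CCOc1ccc2[nH]c(-c3ccc(OC)cc3)c(C3=C(Br)C(=O)NC3=O)c2c1` and compound 2 `CCCOc1ccc2[nH]c(-c3ccc(OC)cc3)c(C3=C(Br)C(=O)NC3=O)c2c1` share one core. In a physicochemical assay for lipophilicity (on this read-out higher numbers stand for higher lipophilicity and lower numbers for lower lipophilicity), compound 1 gives 2.77, and compound 2 gives 3.12. The change between them is methyl in place of hydrogen on a saturated chain carbon, two bonds along the chain from an oxygen on an aromatic ring, and it made a step of a number 0.35 log units higher from compound 1 to compound 2 (beyond the scatter). Compound 3 `CCc1ccc2[nH]c(-c3ccccc3)c(C3=C(Br)C(=O)NC3=O)c2c1` rests on another core; the difference between the two cores is not broken down here. In this assay compound 3 gives 3.15. Compound 4 `CCCc1ccc2[nH]c(-c3ccccc3)c(C3=C(Br)C(=O)NC3=O)c2c1` has not yet been measured. Its change from compound 3 is methyl in place of hydrogen on a saturated chain carbon, two bonds along the chain from an aromatic carbon. This is the same kind of change as that from compound 1 to compound 2, but the place differs: there the saturated chain carbon lies two bonds along the chain from an oxygen on an aromatic ring, here two bonds along the chain from an aromatic carbon. A step of similar size is expected, namely a number 0.35 log units higher from compound 3 to compound 4 (beyond the scatter), since the same kind of change gave a number 0.35 log units higher from compound 1 to compound 2 (beyond the scatter). Compound 4 is therefore estimated at 3.5, between 3.2 and 3.8.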

Compound 4, partition coefficient: 3.43
Compound 4: the middle estimate sits 0.07 log units above what was measured; the measured number falls inside the stated range.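

In this assay the change gave a number 0.35 log units higher from compound 1 to compound 2 (beyond the scatter) on one core and a number 0.28 log units higher from compound 3 to compound 4 (within the scatter) on the other, so the step that stood clear of the scatter on the first cannot be told from the scatter on the second. With one pair on each core, and the place of the change differing as well, this does not show that the step carries over at a fixed size, nor that the core or the place alters it. No measurement at hand explains either step.

As far as these compounds go, it remains open whether a butyl chain would extend the same kind of step on either core. From the compounds shown here alone, it is also open how an amine or a carboxylic acid at the end of the chain would read in this assay on these cores.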